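Ring-nitrogen substituents on the shared core: benzyl

The source may report more compounds than this note shows. Statements on the series, on what has been measured and on what is new or still open speak of the compounds shown alone.

The shared core of compound 1 `O=C1NC(=O)C2(CC2c2ccc3cccc(OCc4ccccc4)c3n2)N1` is tested in a functional assay on the whole organism (strain Kunming) with Mus musculus as the target, with a stated time of 0.5 h (a higher number here means that more compound is needed for the effect, a lower number that less compound is needed), where compound 1 gives 300 mg/kg. Compound 2 `O=C1NC2(CC2c2ccc3cccc(OCc4ccccc4)c3n2)C(=O)N1C1CCCCC1` gives 300 mg/kg in this assay, and compound 3 `CCC(CO)N1C(=O)NC2(CC2c2ccc3cccc(OCc4ccccc4)c3n2)C1=O` gives 100 mg/kg. On these numbers compound 1 stands level with compound 2, the two together the highest of the three, while compound 3 sits lowest: the step of a 3.0-fold lower number from compound 1 to compound 3 (0.48 log units; beyond the scatter) and the step of a 3.0-fold lower number from compound 2 to compound 3 (0.48 log units; beyond the scatter) are both beyond the scatter, whereas no change at the digits printed from compound 1 to compound 2 (within the scatter) is not.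

Compound 4 `O=C1NC2(CC2c2ccc3cccc(OCc4ccccc4)c3n2)C(=O)N1Cc1ccccc1` carries the change (benzyl in place of hydrogen on an amide-type nitrogen in a ring). Going by the values given here, the steps that bear on it are the two from compound 1: the hydrocarbon substituent of compound 2 left the number unchanged, and only the hydroxyl-bearing substituent of compound 3 lowered it. Benzyl, with no donors or acceptors, is closer in kind to cyclohexyl, so no step beyond the scatter is expected from compound 1 to compound 4, no change at the digits printed from compound 1 to compound 4 (within the scatter). Compound 4 is therefore estimated at 300 mg/kg in this assay, with a range from 100 mg/kg to 600 mg/kg.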

Compound 4, minimum effective dose: 300 mg/kg
Estimate against measurement, compound 4: no gap at the digits printed, and the stated range covers the measured number.
By their numbers in this assay, from the lowest: compound 3; then compounds 1, 2 and 4 (each within the scatter of the next).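

In this assay, benzyl on the amide-type nitrogen in a ring gives no change at the digits printed from compound 1 to compound 4 (within the scatter) and so adds a six-membered aromatic ring with no visible effect on the number. Cyclohexyl and benzyl are not separated either, with no change at the digits printed from compound 2 to compound 4 (within the scatter) as the step between them. Hydrogen, cyclohexyl and benzyl now stand level, and compound 3 alone goes against this, with a 3.0-fold higher number from compound 3 to compound 4 (0.48 log units; beyond the scatter) as the step from its 1-(hydroxymethyl)propyl group to benzyl; no independent evidence accompanies these numbers.

Open, from the compounds shown here alone, is whether the lower number of compound 3 goes with its hydroxyl or with the chain that carries it. A plain butyl group, a shorter hydroxyethyl group, or a chain ending in an amine or a carboxylic acid on the same nitrogen would separate these readings.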